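Replacing a Methyl with a Fluoro on Compound 1

This account rests on a few compounds, and the source may have more. Where it says the series, first, only, none or still open, it means among the compounds named here.

In a functional assay on A549 cells (Homo sapiens) for antiproliferative activity, read by MTT assay, with a stated time of 24 h (on this read-out higher numbers stand for weaker inhibition and lower numbers for stronger inhibition), compound 1 `Cc1ccc(-c2nn(-c3ccccc3)cc2-c2nc3ccccc3n2S(=O)(=O)c2ccccc2)cc1` gives 760 nM. Compound 2 `Cc1ccc(-c2nn(-c3ccccc3)cc2-c2nc3ccccc3n2S(=O)(=O)c2ccc(C)cc2)cc1` gives 460 nM, and compound 3 `Cc1ccc(-c2nn(-c3ccccc3)cc2-c2nc3ccccc3n2S(=O)(=O)c2ccc(Cl)cc2)cc1` gives 3550 nM. Compound 1 is therefore level with one neighbour, as a 1.7-fold lower number from compound 1 to compound 2 (0.22 log units; within the scatter) shows, and clearly separated from the other, as a 4.7-fold higher number from compound 1 to compound 3 (0.67 log units; beyond the scatter) shows.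

The next molecule, compound 4 `O=S(=O)(c1ccccc1)n1c(-c2cn(-c3ccccc3)nc2-c2ccc(F)cc2)nc2ccccc21`, keeps the core of compound 1 and alters a single group: fluoro in place of methyl on an aromatic carbon. In words, this is fluoro in place of methyl on an aromatic carbon, para to a large group, turning 4-methylphenyl into 4-fluorophenyl.

For the measured compounds named here, no measured step touches this group, since all three change a different aromatic ring, so any guidance is indirect. The closest in kind is the replacement of methyl by chloro, a 7.7-fold higher number from compound 2 to compound 3 (0.89 log units; beyond the scatter), which points to a weaker compound. Fluoro is a different group on a different ring, however, so only part of that size is carried over. The step expected in this assay is a 1.4-fold higher number from compound 1 to compound 4 (0.16 log units; within the scatter), which may well not exceed the scatter.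

For compound 4 the estimated value is 1100 nM, with an expected range from 350 nM to 3500 nM.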

Compound 4, half-maximal inhibitory concentration: 550 nM
For compound 4 the middle estimate is 2.0-fold (0.30 log units) above the measured one; the measured number falls inside the stated range.
By their numbers in this assay, from the lowest: compounds 2, 4 and 1 (each within the scatter of the next); then compound 3.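

In this assay, turning 4-methylphenyl into 4-fluorophenyl gives a 1.4-fold lower number from compound 1 to compound 4 (0.14 log units; within the scatter), so compound 1 and compound 4 are level and this position accepts fluoro in place of methyl without a change that can be told from the scatter. For the compounds shown here, this is the first measured step at this group, since the earlier steps all changed a different aromatic ring. Going by these compounds alone, the clear rise seen with chloro in place of methyl on that other ring, a 7.7-fold higher number from compound 2 to compound 3 (0.89 log units; beyond the scatter), has no counterpart here, although the group and the ring both differ, so the two influences cannot be separated. Nothing measured here speaks to why methyl and fluoro read alike in this position.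

The compounds shown leave open whether this position stays just as accepting of a much different group, such as an amine, a carboxylic acid or a longer chain like butyl. They also leave open whether chloro at this position, or fluoro on the other ring, would show that the rise belongs to the group rather than to the ring that carries it.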